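Dithiocarbamate series: amine variation on the thiocarbonyl carbon

A few compounds are considered here, and "the series" means these few. Any claim that something is new, unique, unknown or untested is made for them only; others in the source may bear on it.

Measured compounds:
compound 1 `Nc1ccccc1NC(=O)c1ccc(CSC(=S)N2CCCc3ccccc32)cc1`, 38.5%
compound 2 `CCN(Cc1ccncc1)C(=S)SCc1ccc(C(=O)Nc2ccccc2N)cc1`, 71.6%
compound 3 `CC1CCN(C(=S)SCc2ccc(C(=O)Nc3ccccc3N)cc2)CC1`, 28.1%

In a functional assay on MGC-803 cells (Homo sapiens) for antiproliferative activity, read by CCK-8 assay, with a stated time of 72 h, tested at 2 uM (a lower number here means a weaker effect, a higher number a stronger effect of the compound at the concentration tested), compound 3 gives 28.1%, the lowest of the three numbers. Its nearest neighbour is compound 1, from which a number 10.4 percentage points lower from compound 1 to compound 3 (beyond the scatter); the furthest is compound 2, from which a number 43.5 percentage points lower from compound 2 to compound 3 (beyond the scatter). Compound 4 `CN(Cc1cccnc1)C(=S)SCc1ccc(C(=O)Nc2ccccc2N)cc1` differs from compound 3 only at the thiocarbonyl carbon: methyl((pyridin-3-yl)methyl)amino in place of 4-methylpiperidin-1-yl on a thiocarbonyl carbon.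

Among the compounds with values here, the step that bears most directly on this is the one between compound 2 and compound 3, where an open-chain pyridinylmethyl-bearing amine was replaced by the 4-methylpiperidin-1-yl group and a number 43.5 percentage points lower from compound 2 to compound 3 (beyond the scatter). The move from compound 3 to compound 4 reverses that kind of exchange, with methyl in place of ethyl and a pyridin-3-yl in place of a pyridin-4-yl. Compound 1 to compound 2, a number 33.1 percentage points higher from compound 1 to compound 2 (beyond the scatter), points the same way. A large rise in this assay is therefore expected, a number 33.9 percentage points higher from compound 3 to compound 4 (beyond the scatter), though the smaller alkyl and the different pyridine attachment leave the size uncertain. Compound 4 is estimated at 62%, within 42% to 80%.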

Compound 4, a percentage reported as inhibition, at one concentration (the size of the read-out at that concentration, not a potency): 45.9%
The estimate for compound 4 lay 16.1 percentage points above the measured number; low and high end bracket the measured number.
By their numbers in this assay, from the lowest: compound 3; then compounds 1 and 4 (each within the scatter of the next); then compound 2.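

Notes on the thiocarbonyl carbon: in this assay the open-chain amine methyl((pyridin-3-yl)methyl)amino improves on 4-methylpiperidin-1-yl, with a number 17.8 percentage points higher from compound 3 to compound 4 (beyond the scatter) as the step, but this gain is smaller than the one seen with ethyl((pyridin-4-yl)methyl)amino. A pyridinylmethyl amine at this position is therefore not enough by itself to reach the level of compound 2, as a number 25.7 percentage points lower from compound 2 to compound 4 (beyond the scatter) shows, and this step changes both the alkyl group and the pyridine attachment. The tetrahydroquinoline comparison gives a number 7.4 percentage points higher from compound 1 to compound 4 (within the scatter) and so does not separate these two amines.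

From the compounds shown here alone, it remains open whether the alkyl group or the pyridine attachment accounts for the drop, and methyl((pyridin-4-yl)methyl)amino or ethyl((pyridin-3-yl)methyl)amino would separate the two. No measurement available here explains the differences among these amines.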